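The source may report more compounds than this note shows. Statements on the series, on what has been measured and on what is new or still open speak of the compounds shown alone.

Compounds measured in a functional assay on SAOS-2 cells (Homo sapiens) for antiproliferative activity, read by MTT assay, with a stated time of 72 h; on this read-out higher numbers stand for weaker inhibition and lower numbers for stronger inhibition:
compound 1 `O=C(C1=C(O)C(=O)N(CCCn2ccnc2)C1c1ccc(Br)cc1)c1ccccc1` — 31600 nM
compound 2 `O=C(C1=C(Nc2ccc(Cl)cc2)C(=O)N(CCCn2ccnc2)C1c1ccc(Br)cc1)c1ccccc1` — 24800 nM

Compound 1 stands at the higher of the two numbers, but its nearest neighbour is compound 2, and the step of a 1.3-fold lower number from compound 1 to compound 2 (0.11 log units; within the scatter) lies within the scatter, so the two compounds cannot be told apart on this read-out. For the measured compounds named here, the step from compound 1 to compound 2 is the one measured change of the set: a (4-chlorophenyl)amino group in place of hydroxy on a double-bonded ring carbon of the shared core.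

Compound 3 `O=C(C1=C(Nc2ccc(OC(F)(F)F)cc2)C(=O)N(CCCn2ccnc2)C1c1ccc(Br)cc1)c1ccccc1` has not yet been measured in this assay. It differs from compound 1 by (4-(trifluoromethoxy)phenyl)amino in place of hydroxy on a double-bonded ring carbon. Going by the values given here, this is the same kind of exchange at the same place as the one from compound 1 to compound 2, where the arylamino group produced a step within the scatter. Among the compounds with values here, that single step is the only guide available, and it points to no movement beyond the scatter for compound 3. The step of a 1.3-fold lower number from compound 1 to compound 3 (0.10 log units; within the scatter) is therefore expected to be small. Compound 3 is estimated at 25000 nM, within a range of 10000 nM to 63000 nM.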

Compound 3, half-maximal inhibitory concentration: 17900 nM
For compound 3 the middle estimate is 1.4-fold (0.15 log units) above the measured one, within the range that was stated.
By their numbers in this assay, from the lowest: compounds 3, 2 and 1 (each within the scatter of the next).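

In this assay, the step of a 1.8-fold lower number from compound 1 to compound 3 (0.25 log units; within the scatter) shows that a second arylamino group on the double-bonded ring carbon next to the ring atom that bears the benzoyl group also stays within the scatter of the hydroxy compound, so the result at this position no longer rests on the single (4-chlorophenyl)amino example. The new comparison within the aryl group, trifluoromethoxy in place of chloro on an aromatic carbon, gives the step of a 1.4-fold lower number from compound 2 to compound 3 (0.14 log units; within the scatter) and so does not separate these two groups on this read-out, while the hydroxy of compound 1 and the 12 heavy atoms of the (4-(trifluoromethoxy)phenyl)amino group of compound 3 also cannot be told apart here. Nothing available gives a reason for these numbers.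

Still open, as far as these compounds go, is whether a simple alkylamine such as dimethylamino, with no aromatic ring, would leave the number within the scatter at this position. Equally open, from the compounds shown here alone, is whether a carboxylic acid or a dimethylamino group in place of chloro or trifluoromethoxy on the aryl ring would move the number beyond the scatter.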